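Furan isomer swap in a piperidine urea series

The compounds below may be only part of what the source reports. "The series", "measured", "known", "first", "only" and "open" are said of these compounds alone.

Solubility values in a physicochemical assay for solubility, read by mass spectrometry, in phosphate buffer, with a stated time of 24 h, at pH 7.4 (a higher number here means a more soluble compound, a lower number a less soluble compound), for the three measured compounds:
compound 1 `Cc1occc1C(=O)N1CCC(NC(=O)Nc2ccc(OC(F)(F)F)cc2)CC1` gives 8.6 ug/mL;
compound 2 `O=C(CC1CCN(C(=O)C2CC2)CC1)Nc1ccc(OC(F)(F)F)c(F)c1` gives 715 ug/mL;
compound 3 `O=C(Nc1ccc(C(F)(F)F)cc1)NC1CCN(C(=O)C2CCOC2)CC1` gives 9.6 ug/mL.

Compound 1 stands lowest of the three numbers. Compound 3 sits within the scatter of it, so no order between those two can be read. Compound 2 lies far above both, beyond the scatter.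

Compound 4 `Cc1ccoc1C(=O)N1CCC(NC(=O)Nc2ccc(OC(F)(F)F)cc2)CC1` keeps every atom of compound 1 and rearranges only the furan substituent on the carbonyl carbon: 3-methylfuran-2-yl in place of 2-methylfuran-3-yl on a carbonyl carbon. Among the compounds with values here, no measured pair in this assay shows a change of this kind, so the size of the step is unknown from the data. The expectation is a step from compound 1 to compound 4 of a 1.0-fold higher number from compound 1 to compound 4 (0.02 log units; within the scatter), none beyond the scatter. Compound 4 is estimated at 9 ug/mL, with a range of 4 ug/mL to 20 ug/mL.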

Compound 4, solubility: 0.92 ug/mL
Beside the measured number, compound 4's estimate is 9.8-fold (0.99 log units) above it, outside the stated range (below it).
By their numbers in this assay, from the lowest: compound 4; then compounds 1 and 3 (each within the scatter of the next); then compound 2.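

In this assay the position on the carbonyl carbon proves sensitive to the furan arrangement alone: 3-methylfuran-2-yl in place of 2-methylfuran-3-yl gives a 9.3-fold lower number from compound 1 to compound 4 (0.97 log units; beyond the scatter) even though the atoms and the donor and acceptor counts stay the same. Within the data shown here, this is the first readable step. Nothing available accounts for its size.

From the compounds shown here alone, whether a furan bearing an amine or a carboxylic acid in place of the methyl would differ from compound 1 or compound 4 stays open. So does whether the same swap gives a step of this size on another core.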